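Aryl exchange from compound 3 to compound 4

The source may hold more compounds than are shown below. What is called first, only, known or untested is meant among the compounds shown, and "the series" means these compounds.

In an ADME assay on BHK-21 cells (Mesocricetus auratus) for cytotoxicity, read by MTT assay, with a stated time of 96 h (a higher number here means that more compound is tolerated, a lower number that less compound is tolerated), compound 3 `Fc1ccc(/N=N/c2ccc(NC[C@@H]3CCCN4CCCC[C@H]34)c3c2CCCC3)c(F)c1` stands lowest at 9000 nM and compound 1 `Fc1ccc(F)c(/N=N/c2ccc(NC[C@@H]3CCCN4CCCC[C@H]34)c3c2CCCC3)c1` follows at 38000 nM in the same read-out. Compound 2 `c1ccc(/N=N/c2ccc(NC[C@@H]3CCCN4CCCC[C@H]34)c3c2CCCC3)cc1` gives > 100000 nM as a limit of this assay and not as a number. The move to compound 4 `FC(F)(F)c1cccc(/N=N/c2ccc(NC[C@@H]3CCCN4CCCC[C@H]34)c3c2CCCC3)c1` is 3-(trifluoromethyl)phenyl in place of 2,4-difluorophenyl on a double-bonded nitrogen on the shared core. Two measured exchanges at this place bear on it: the modest 4.2-fold lower number from compound 1 to compound 3 (0.63 log units; beyond the scatter) and the large at least 11-fold lower number from compound 2 to compound 3 (1.04 log units; beyond the scatter). Neither involves trifluoromethyl, and both end at the lowest number in the series, so a modest move to a higher number is expected (a 2.2-fold higher number from compound 3 to compound 4 (0.35 log units; beyond the scatter)). For compound 4 the estimated value is 20000 nM with an expected range (6000 nM to 70000 nM).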

Compound 4, half-maximal cytotoxic concentration: 14000 nM
Compound 4: middle estimate off by 1.4-fold (0.15 log units), on the high side; measured number inside the range.
By their numbers in this assay, from the lowest: compounds 3 and 4 (each within the scatter of the next); then compound 1. At a limit, above all of these: compound 2.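

In this assay, a 1.6-fold higher number from compound 3 to compound 4 (0.19 log units; within the scatter) leaves 3-(trifluoromethyl)phenyl unseparated from 2,4-difluorophenyl at this place, while a 2.7-fold lower number from compound 1 to compound 4 (0.43 log units; beyond the scatter) keeps 2,5-difluorophenyl apart from it. Trifluoromethyl in place of hydrogen on an aromatic carbon accounts for an at least 7.1-fold lower number from compound 2 to compound 4 (0.85 log units; beyond the scatter), so a single group on the phenyl ring is enough for a step of this size. That step rests on a limit for compound 2 and not on a number: the limit of > 100000 nM in this assay, at which 1 of the 4 values shown sits.

From the compounds shown here alone, whether an amine or a carboxylic acid on this ring would give a number nearer compound 2 stays open. So does whether a nitrile would behave like trifluoromethyl.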